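The source may hold more compounds than are shown below. What is called first, only, known or untested is meant among the compounds shown, and "the series" means these compounds.

Working notes on the series. The shared core of compound 1 `Cc1c(Cc2ccc(Cl)cc2)c(=O)oc2cc(OCC(O)CN3CCC(C(N)=O)CC3)ccc12` carries a chloro group; in an ADME assay on A549 cells (Homo sapiens) for cytotoxicity, read by CellTiter-Glo (on this read-out higher numbers stand for lower toxicity in this test and lower numbers for higher toxicity in this test), compound 1 gives 40000 nM. Compound 2 `Cc1c(Cc2ccc(Br)cc2)c(=O)oc2cc(OCC(O)CN3CCC(C(N)=O)CC3)ccc12` has bromo in place of chloro. In this assay compound 2 reaches only the limit of > 100000 nM. Compound 3 `Cc1c(Cc2ccc(-c3ccccc3)cc2)c(=O)oc2cc(OCC(O)CN3CCC(C(N)=O)CC3)ccc12` carries a phenyl in place of the chloro. In this assay compound 3 likewise sits at the limit of > 100000 nM, so only a limit is known for it, and it stands with compound 2 at the upper edge of the numbers shown (the limit of > 100000 nM in this assay, at which 2 of the 3 values shown sit). The measured steps read an at least 2.5-fold higher number from compound 1 to compound 2 (0.39 log units; beyond the scatter) and an at least 2.5-fold higher number from compound 1 to compound 3 (0.39 log units; beyond the scatter), while a step that the two limits leave unreadable from compound 2 to compound 3.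

Compound 4 `Cc1c(Cc2ccc(-c3ccc(F)cc3)cc2)c(=O)oc2cc(OCC(O)CN3CCC(C(N)=O)CC3)ccc12` differs from compound 3 by fluoro in place of hydrogen on an aromatic carbon. Both steps that reach compound 3 end at the limit, so no readable direction for a further change at that position exists. Compound 4 is therefore expected to remain at or near the limit, with an estimated step of a number no higher from compound 3 to compound 4 (the limit leaves the size open). The estimate for compound 4 in this assay is 100000 nM, between 40000 nM and 300000 nM.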

Compound 4, half-maximal cytotoxic concentration: 19300 nM
Compound 4: middle estimate off by 5.2-fold (0.71 log units), on the high side; measured number below the stated range.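

In this assay, this place on the added phenyl ring proves sensitive: fluoro in place of hydrogen gives an at least 5.1-fold lower number from compound 3 to compound 4 (0.71 log units; beyond the scatter), so a phenyl in place of chloro does not by itself hold the read-out at the limit. For the compounds shown here, the 4-fluorophenyl group in place of the halogens gives an at least 5.1-fold lower number from compound 2 to compound 4 (0.71 log units; beyond the scatter) and a 2.1-fold lower number from compound 1 to compound 4 (0.32 log units; beyond the scatter), which puts compound 4 lowest of the four, although the earlier steps away from chloro had all gone upward. The first of these two steps and the fluoro step have no upper size, because compound 2 and compound 3 each stand only at a limit: the limit of > 100000 nM in this assay, at which 2 of the 4 values shown sit.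

Going by these compounds, whether the fall belongs to fluoro alone or to any group at this place stays open. A methoxy group, an amine or a carboxylic acid there would test this.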